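A Weak Inhibitor, a Benzamido Exchange, an Expectation

The source may report more compounds than this note shows. Statements on the series, on what has been measured and on what is new or still open speak of the compounds shown alone.

Measured so far:
Compound 1 `COc1cc(/C=C/C(C)=O)ccc1OCc1cn(-c2ccc(/N=N/c3ccccc3)cc2)nn1` — 75900 nM
Compound 2 `COc1cccc(-n2cc(COc3ccc(/C=C/C(C)=O)cc3OC)nn2)c1` — 1800 nM

Two compounds were tested in a functional assay on MCF7 cells (Homo sapiens) for antiproliferative activity, read by MTT assay, with a stated time of 48 h; a lower number here means a stronger inhibitor, a higher number a weaker inhibitor. Compound 1 stands at the highest number of the two; its nearest neighbour, compound 2, gives a lower number, and that gap lies beyond the usual scatter. Among the compounds with values here, the two differ in more than one place, so no single step connects them, and the values show only that compound 1 is the weaker of the pair.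

Compound 3 `COc1cc(/C=C/C(C)=O)ccc1OCc1cn(-c2ccc(NC(=O)c3ccccc3)cc2)nn1` differs from compound 1 in one place: a group of 9 heavy atoms (7 carbon, 1 nitrogen, 1 oxygen; one six-membered aromatic ring of carbon only) in place of a group of 8 heavy atoms (6 carbon, 2 nitrogen; one six-membered aromatic ring of carbon only), on an aromatic carbon. Within the data shown here, nothing among the measured compounds isolates a change of this kind, so the size of the step has no measured precedent. Among the measured compounds shown here, the account expects a modest move toward a lower number, given only that compound 1 sits at the weak end of what has been seen; the expected step is a 3.0-fold lower number from compound 1 to compound 3 (0.48 log units; beyond the scatter). On that basis compound 3 is estimated at 25000 nM, with a range from 5000 nM to 100000 nM.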

Compound 3, half-maximal inhibitory concentration: 86700 nM
Compound 3: the middle estimate sits 3.5-fold (0.54 log units) below what was measured; measured number inside the range.
By their numbers in this assay, from the lowest: compound 2; then compounds 1 and 3 (each within the scatter of the next).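

In this assay, within the data shown here, benzamido entering on an aromatic carbon para to a large group, in place of the group carried by compound 1, gives a 1.1-fold higher number from compound 1 to compound 3 (0.06 log units; within the scatter) and so provides the first measured step at this position. The two groups share a six-membered aromatic ring of carbon only and a double bond outside it, but they differ in their counts: benzamido has one hydrogen-bond donor and one acceptor, while the group it replaces has no donor and two acceptors, and this difference leaves the two compounds within the scatter of each other. No independent measurement bears on why these two groups read alike.

Going by these compounds, whether any group at this position can move the number beyond the scatter remains open, and an amine or a carboxylic acid on that aromatic carbon, neither carrying such a ring, would put this to a sharper test. Compound 2 differs from compound 1 and compound 3 in more than one place, so its value cannot be assigned to any single change.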